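The source may report more compounds than this note shows. Statements on the series, on what has been measured and on what is new or still open speak of the compounds shown alone.

Three compounds have been measured so far in a functional assay on BXPC-3 cells (Homo sapiens) for inhibition, read by MTT assay, with a stated time of 7 days; a higher number here means a weaker inhibitor, a lower number a stronger inhibitor:

Compound 1, `CCN(CC)S(=O)(=O)c1ccc(S(=O)(=O)N2CCC[C@@H](C(=O)NC3CN(S(C)(=O)=O)C3)C2)cc1`: 7400 nM
Compound 2, `CCN(CC)S(=O)(=O)c1ccc(S(=O)(=O)N2CCC[C@@H](C(=O)NC3COC3)C2)cc1`: 13800 nM
Compound 3, `CCN1CC(NC(=O)[C@@H]2CCCN(S(=O)(=O)c3ccc(S(=O)(=O)N(CC)CC)cc3)C2)C1`: > 30000 nM

The value of compound 3 is a limit of the assay, not a number, so its true potency is weaker than any figure shown. Its weakness stands out in the steps leading to it: an at least 4.0-fold higher number from compound 1 to compound 3 (0.60 log units; beyond the scatter) and an at least 2.1-fold higher number from compound 2 to compound 3 (0.33 log units; beyond the scatter) both run towards the weak end, and compound 3 sits at the limit of > 30000 nM in this assay, at which 1 of the 3 values shown sits.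

Compound 4, `CCN(CC)S(=O)(=O)c1ccc(S(=O)(=O)N2CCC[C@@H](C(=O)N[C@H]3CCN(C(=O)OC(C)(C)C)C3)C2)cc1`, differs from compound 3 in one place: 1-(tert-butoxycarbonyl)pyrrolidin-3-yl in place of 1-ethylazetidin-3-yl on an amide-type nitrogen. The step that bears most directly on this change is an at least 4.0-fold higher number from compound 1 to compound 3 (0.60 log units; beyond the scatter), where ethyl in place of methylsulfonyl on the ring nitrogen weakened inhibition beyond the scatter. For the measured compounds named here, in compound 4 the ring nitrogen again carries a tert-butoxycarbonyl group rather than ethyl, which returns to the kind of substitution seen in compound 1, so a step back towards stronger inhibition is expected, though the ring is now five-membered rather than four-membered, for which no measured step exists. Compound 4 is therefore expected to give about 9000 nM in this assay, with a range from 3000 nM to 30000 nM. Against compound 3 this expectation amounts to an at least 3.3-fold lower number from compound 3 to compound 4 (0.52 log units; beyond the scatter).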

Compound 4, half-maximal inhibitory concentration: 300 nM
For compound 4 the middle estimate is 30-fold (1.48 log units) above the measured one, and the stated range ends above it.
By their numbers in this assay, from the lowest: compound 4; then compounds 1 and 2 (each within the scatter of the next). At a limit, above all of these: compound 3.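

In this assay, for the compounds shown here, the group on the amide-type nitrogen proves able to move inhibition much further than the earlier compounds showed, with an at least 100-fold lower number from compound 3 to compound 4 (2.00 log units; beyond the scatter). Compound 3 stands at a limit, not a number: the limit of > 30000 nM in this assay, at which 1 of the 4 values shown sits.

The new group, 1-(tert-butoxycarbonyl)pyrrolidin-3-yl, also compares well with the two groups that gave measured numbers, with a 46-fold lower number from compound 2 to compound 4 (1.66 log units; beyond the scatter) and a 25-fold lower number from compound 1 to compound 4 (1.39 log units; beyond the scatter), so this position can carry a far stronger inhibitor than oxetan-3-yl or 1-(methylsulfonyl)azetidin-3-yl.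

This change alters the ring size and the group on the ring nitrogen together, so the compounds shown cannot separate the two. From the compounds shown here alone, a pyrrolidin-3-yl ring bearing methylsulfonyl on its nitrogen, or a free ring amine, would help to show which part matters, and the opposite stereocentre remains open too.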